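A few compounds are considered here, and "the series" means these few. Any claim that something is new, unique, unknown or untested is made for them only; others in the source may bear on it.

Measured compounds: compound 1 `CCCCCCCC/C=C/CCCCCCCC(=O)Nc1ccccc1OC`, in an assay on microsomes from intestine for inhibition of acyl-CoA:cholesterol acyltransferase (Oryctolagus cuniculus) (on this read-out lower numbers stand for stronger inhibition and higher numbers for weaker inhibition), compound 1 gives 8000 nM; compound 2 `CCCCCCCC/C=C/CCCCCCCC(=O)Nc1c(C)cccc1OCC`, in this assay compound 2 gives 15 nM.

Within the data shown here, compound 2 holds the lower of the two numbers; the only measured step is a 530-fold lower number from compound 1 to compound 2 (2.73 log units; beyond the scatter). Compound 3 `CCCCCCCC/C=C/CCCCCCCC(=O)Nc1c(C)cccc1C(C)C` differs from compound 2 by isopropyl in place of ethoxy on an aromatic carbon. That measured step changed the other substituent of the shared core together with the alkoxy chain length, so it does not address an exchange of ethoxy for isopropyl. Among the measured compounds shown here, no measured pair bears directly on this change. For compound 3 the expected step is a 1.3-fold lower number from compound 2 to compound 3 (0.10 log units; within the scatter), within the scatter. Compound 3 is estimated at 12 nM, between 3 nM and 50 nM.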

Compound 3, half-maximal inhibitory concentration: 23 nM
The estimate for compound 3 lay 1.9-fold (0.28 log units) below the measured number; measured number inside the range.
By their numbers in this assay, from the lowest: compounds 2 and 3 (each within the scatter of the next); then compound 1.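

In this assay, isopropyl in place of ethoxy on this aromatic carbon gives a 1.5-fold higher number from compound 2 to compound 3 (0.19 log units; within the scatter), so at this position the low number does not depend on the oxygen of ethoxy. With a 350-fold lower number from compound 1 to compound 3 (2.54 log units; beyond the scatter) on the series, the large gain over compound 1 also holds for a group without oxygen at this place. Nothing measured here gives a reason for either step.

The methyl group and the second substituent still change together relative to compound 1, so their shares of that gain stay unseparated. As far as these compounds go, whether tert-butyl or an amine at this position keeps the number stays open.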